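Replacing a hydroxycyclohexyl amide substituent with a fused bicycle

The source may report more compounds than this note shows. Statements on the series, on what has been measured and on what is new or still open speak of the compounds shown alone.

Measured compounds:
Compound 1, `CNC(=O)c1cc(C(=O)N[C@H]2[C@@H]3COC[C@@H]32)cc2c1OC[C@H]2c1ccccc1`: 3.3
Compound 2, `CNC(=O)c1cc(C(=O)N[C@H]2CC[C@H](O)CC2)cc2c1OC[C@@]2(C)c1ccccc1`: 3.3
Compound 3, `CNC(=O)c1cc(C(=O)NC)c2c(c1)[C@H](c1ccccc1)[C@@H](CF)O2`: 3.3

In a physicochemical assay for lipophilicity, at pH 7.4 (on this read-out lower numbers stand for lower lipophilicity and higher numbers for higher lipophilicity), compound 2 gives 3.3. In this assay compound 1 gives 3.3. In this assay compound 3 gives 3.3. The three measured values are level at the digits shown, so compound 2 stands neither apart from nor ahead of its two companions; the spread between them lies within the scatter of repeated measurements.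

The next compound, compound 4, `CNC(=O)c1cc(C(=O)N[C@H]2[C@@H]3C[C@@H](O)C[C@@H]32)cc2c1OC[C@@]2(C)c1ccccc1`, has not yet been measured. It is reached from compound 2 by one change:
a group of 7 heavy atoms (6 carbon, 1 oxygen; one three-membered non-aromatic ring of carbon only, one five-membered non-aromatic ring of carbon only) in place of a group of 7 heavy atoms (6 carbon, 1 oxygen; one six-membered non-aromatic ring of carbon only), on an amide-type nitrogen

For the measured compounds named here, no pair among the measured compounds differs in just this one place, so there is no measured step to lean on. Both groups carry the same number of heavy atoms and the same count of donor and acceptor, and the difference is only in how the ring carbons are arranged. For that reason only a small step is expected, of the size given by a number 0.10 log units lower from compound 2 to compound 4 (within the scatter), with no clear direction beyond the scatter. Compound 4 is therefore expected to give about 3.2, somewhere between 2.8 and 3.6.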

Compound 4, distribution coefficient: 3.3
Compound 4: middle estimate off by 0.10 log units, on the low side; the range from low to high includes it.
By their numbers in this assay, from the lowest: compounds 1, 2, 3 and 4 (each within the scatter of the next).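

In this assay, replacing the 4-hydroxycyclohexyl group on the amide-type nitrogen with the group that holds a three-membered and a five-membered carbon ring gives no change at the digits printed from compound 2 to compound 4 (within the scatter). For the compounds shown here, this is the first step in the set that isolates a single change at this place, since the earlier compounds differ from one another in more than one place. It shows that, for this pair, the two groups can be exchanged without moving the read-out beyond the scatter, even though they have the same heavy atoms and hydrogen-bond donor and acceptor counts but different ring arrangements; no other data here bear on why.

As far as these compounds go, whether the same holds for a group of another kind on this nitrogen, such as one carrying an amine or a carboxylic acid, stays open. So does the outcome of this exchange on the core of compound 1.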